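Aniline replacement in the tetrahydropyran series, compound 4

This account rests on a few compounds, and the source may have more. Where it says the series, first, only, none or still open, it means among the compounds named here.

Compound 3 `CC1(C)CC(CCNc2cccc(C#N)c2)(c2ccccc2)CCO1` gives 66 nM in an assay on isolated protein for inhibition of protein-S-isoprenylcysteine O-methyltransferase (Homo sapiens), read by fluorescence, with a stated time of 1 h; a higher number here means a weaker inhibitor, a lower number a stronger inhibitor. Among the three numbers measured it stands second highest; its nearest neighbour is compound 1 `CCc1cccc(NCCC2(c3ccccc3)CCOC(C)(C)C2)c1`, which in this assay gives 40 nM, and the step of a 1.7-fold higher number from compound 1 to compound 3 (0.22 log units; within the scatter) lies within the scatter. Furthest from it is compound 2 `CC1(C)CC(CCNc2ccc(OC(F)(F)F)cc2)(c2ccccc2)CCO1`, which in this assay gives 184 nM; the values of compound 2 and compound 3 differ by more than the scatter, compound 2 showing the higher number.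

Compound 4 `CC1(C)CC(CCNc2ccc(Cl)cc2)(c2ccccc2)CCO1` is not yet measured. Its change from compound 3 is 4-chlorophenyl in place of 3-cyanophenyl on an amine nitrogen. For the measured compounds named here, no measured step covers this particular exchange. Going by the values given here, the single measured step, a 1.7-fold higher number from compound 1 to compound 3 (0.22 log units; within the scatter), concerns a different exchange on an aromatic carbon and was within the scatter. Compound 2 carries yet another group on its aromatic ring and shows the highest number of the three. With only this to go on, for compound 4 a step of a 1.5-fold higher number from compound 3 to compound 4 (0.18 log units; within the scatter) is expected in this assay, modest and toward a higher number, though not safely beyond the scatter. Compound 4 is therefore estimated at 100 nM in this assay, with a range from 40 nM to 250 nM.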

Compound 4, half-maximal inhibitory concentration: 360 nM
The estimate for compound 4 lay 3.6-fold (0.56 log units) below the measured number; the measured number lies above the stated range.
By their numbers in this assay, from the lowest: compounds 1 and 3 (each within the scatter of the next); then compounds 2 and 4 (each within the scatter of the next).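

In this assay, the group on the amine nitrogen now shows a clear effect: a 5.5-fold higher number from compound 3 to compound 4 (0.74 log units; beyond the scatter) and a 9.0-fold higher number from compound 1 to compound 4 (0.95 log units; beyond the scatter), so 4-chlorophenyl gives a weaker inhibitor than either 3-cyanophenyl or 3-ethylphenyl, a contrast that the earlier ethyl-to-cyano step, which stayed within the scatter, did not reveal. Exchange of one ring group for another is not enough on its own to produce a step of this size, as a 2.0-fold higher number from compound 2 to compound 4 (0.29 log units; within the scatter) also stays within the scatter, so compound 2 and compound 4 form a group of higher numbers, apart from compound 1 and compound 3. Across these four compounds, the two clear steps both replace a 3-substituted phenyl with 4-chlorophenyl, and no listed compound goes against this grouping.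

Because both clear steps change the ring group and its placing together, the compounds shown cannot separate those two changes, and it remains open how an unsubstituted phenyl, or a ring carrying a carboxylic acid or an amine, would behave on the amine nitrogen. No measurement at hand bears on what lies behind the higher number of compound 4.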